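A few compounds are considered here, and "the series" means these few. Any claim that something is new, unique, unknown or untested is made for them only; others in the source may bear on it.

Compound 1 (`O=C(O)c1ccc2c(c1)no[n+]2[O-]`) supplies the core of this short series, and compound 2 (`O=C(CCCOC(=O)c1ccc2c(c1)no[n+]2[O-])NO`) carries that core as an ester with a hydroxycarbamoyl-ended chain. In a functional assay on B16 cells (Mus musculus) for inhibition, read by MTT assay, with a stated time of 48 h (a higher number here means a weaker inhibitor, a lower number a stronger inhibitor), compound 1 gives "not determined" (no result reported) and so offers no number for comparison. Compound 2 gives 22200 nM as the only number shown, which means it cannot yet be ranked against any other compound. Compound 3 (`O=C(CCCCOC(=O)c1ccc2c(c1)no[n+]2[O-])NO`) differs from compound 2 in one place ((hydroxycarbamoyl)methyl in place of hydroxycarbamoyl on a saturated chain carbon, three bonds along the chain from an oxygen next to a carbonyl group), with (hydroxycarbamoyl)methyl in place of hydroxycarbamoyl on a saturated chain carbon, three bonds along the chain from an oxygen next to a carbonyl group. Among the compounds with values here, no measured pair shows what such a change does. In this assay the expected step of a 1.4-fold lower number from compound 2 to compound 3 (0.14 log units; within the scatter) is small and towards a lower number, perhaps no larger than the usual scatter. Compound 3 is estimated at 16000 nM (expected range 7000 nM to 38000 nM).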

Compound 3, half-maximal inhibitory concentration: 24000 nM
The estimate for compound 3 lay 1.5-fold (0.18 log units) below the measured number; the range from low to high includes it.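

In this assay, within the data shown here, the first measured step for (hydroxycarbamoyl)methyl in place of hydroxycarbamoyl on a saturated chain carbon, three bonds along the chain from an oxygen next to a carbonyl group, is a 1.1-fold higher number from compound 2 to compound 3 (0.03 log units; within the scatter). At this position, the longer chain of compound 3 therefore gives a number that cannot be told apart from that of compound 2. Nothing available explains this result.

Going by these compounds, whether 3-(hydroxycarbamoyl)propyl or a still longer chain would also stay within the scatter remains open, as does the effect of an amine or a carboxylic acid in place of the hydroxycarbamoyl end. On these data alone, compound 1 offers no number for comparison, so what either hydroxycarbamoyl-ended chain adds to the shared core also remains open.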